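Working notes on a trifluoromethyl series: compound 1 to compound 4

The source may hold more compounds than are shown below. What is called first, only, known or untested is meant among the compounds shown, and "the series" means these compounds.

Compound 1 `FC(F)(F)c1cc(NC[C@H]2CCCN2)c2cn[nH]c2c1` is the reference point of these notes. In an assay for inhibition of Tryptophan 2,3-dioxygenase (Homo sapiens), with stated times of 10 min and 60 min, tested at 100 uM (on this read-out higher numbers stand for a stronger effect at the one concentration tested and lower numbers for a weaker effect), compound 1 gives 84%, the second highest of the three numbers at hand. Its nearest neighbour is compound 3 `O=[N+]([O-])c1cc(Br)c(F)cc1CNc1cc(C(F)(F)F)cc2[nH]ncc12`, which in this assay gives 88%, a number higher by a margin that lies within the usual scatter, so no order between compound 1 and compound 3 is claimed. Furthest away is compound 2 `NCCn1ncc2c(NCc3ccccc3[N+](=O)[O-])cc(C(F)(F)F)cc21`, which in this assay gives 29%, a number well beyond the scatter below compound 1.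

The compound not yet measured is compound 4 `FC(F)(F)c1cc(NCc2cccc(Br)c2)c2cn[nH]c2c1`. Against compound 1 the change is 3-bromophenyl in place of pyrrolidin-2-yl on a saturated chain carbon bound to a nitrogen on an aromatic ring. Among the compounds with values here, no step between two measured compounds that differ in one place has been recorded, so the size of the step in this assay is judged from the whole set. A small step is expected, if any beyond the scatter, with a slight lean downward, because compound 3, which also carries a six-membered aromatic ring of carbon only on the saturated chain carbon bound to the ring nitrogen, gives 88% in this assay. For compound 4 the estimate in this assay is 76%, with a range from 50% to 95%. The expected step is a number 8 percentage points lower from compound 1 to compound 4 (within the scatter).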

Compound 4, a percentage reported as inhibition, at one concentration (the size of the read-out at that concentration, not a potency): 84%
Compound 4: the middle estimate sits 8 percentage points below what was measured; the measured number falls inside the stated range.
By their numbers in this assay, from the lowest: compound 2; then compounds 1, 4 and 3 (each within the scatter of the next).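

In this assay, within the data shown here, the exchange of pyrrolidin-2-yl for 3-bromophenyl on a saturated chain carbon bound to a nitrogen on an aromatic ring gives no change at the digits printed from compound 1 to compound 4 (within the scatter) and this is the first step that can be read between two compounds differing in one place. At this position the read-out therefore stays within the scatter while the hydrogen-bond donor, the hydrogen-bond acceptor and the defined stereocentre of pyrrolidin-2-yl leave and a six-membered aromatic ring of carbon only, carrying bromine, enters, although a read-out at one concentration is no measure of potency. No measurement at hand explains why the two groups read alike.

The compounds shown leave open whether bromine itself matters on this ring, since unsubstituted phenyl is not among them, and whether a pyridine ring would read the same. Going by these compounds, it also stays open how a carboxylic acid or a longer chain would read at this place, and whether the mirror-image form of pyrrolidin-2-yl would match compound 1.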